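The source may hold more compounds than are shown below. What is called first, only, known or untested is meant among the compounds shown, and "the series" means these compounds.

Measured compounds:
compound 1 `COc1ccc(OCC(=O)N2CCN(c3ccc(C(F)(F)F)cc3[C@@H](N)CC(C)C)CC2)cc1` — 3800 nM
compound 2 `CC(C)C[C@H](N)c1cc(C(F)(F)F)ccc1N1CCN(C(=O)COc2ccc([N+](=O)[O-])cc2)CC1` — 3100 nM
compound 3 `Cc1ccc(OCC(=O)N2CCN(c3ccc(C(F)(F)F)cc3[C@@H](N)CC(C)C)CC2)c(C)c1` — 4000 nM

All three numbers come from an assay on HEK293 cells for displacement of a labelled ligand from Melanocortin receptor 4 (Homo sapiens); on this read-out lower numbers stand for stronger inhibition and higher numbers for weaker inhibition. Compound 3 is separated from the other two only by steps that stay within the scatter: a 1.1-fold higher number from compound 1 to compound 3 (0.02 log units; within the scatter) and a 1.3-fold higher number from compound 2 to compound 3 (0.11 log units; within the scatter). The third measured step, a 1.2-fold lower number from compound 1 to compound 2 (0.09 log units; within the scatter), is likewise within the scatter. So far, varying the aryl group on the oxygen on a saturated carbon has not moved the read-out beyond repeat-measurement noise.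

Compound 4 `CC(C)C[C@H](N)c1cc(C(F)(F)F)ccc1N1CCN(C(=O)CSc2ccc(Cl)cc2Cl)CC1` is not yet measured. Its difference from compound 3: (2,4-dichlorophenyl)sulfanyl in place of 2,4-dimethylphenoxy on a saturated chain carbon bound to a carbonyl carbon. Within the data shown here, this change goes further than the measured ones, since it replaces the oxygen linker with sulfur as well as exchanging the aryl substituents; no measured pair covers the oxygen-to-sulfur swap. Among the measured compounds shown here, the steps that bear on it are a 1.1-fold higher number from compound 1 to compound 3 (0.02 log units; within the scatter) and a 1.3-fold higher number from compound 2 to compound 3 (0.11 log units; within the scatter), both small, which argue that aryl variation at this position leaves this assay largely unchanged. As far as these compounds go, the linker swap is untested, so the range is set wider than the measured spread.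

For compound 4 the expected step is a 1.3-fold lower number from compound 3 to compound 4 (0.10 log units; within the scatter), i.e. nothing clearly beyond the scatter. Compound 4 is estimated at 3200 nM, with a range from 1200 nM to 8500 nM.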

Compound 4, inhibition constant: 1500 nM
The estimate for compound 4 lay 2.1-fold (0.33 log units) above the measured number, and the stated range covers the measured number.
By their numbers in this assay, from the lowest: compound 4; then compounds 2, 1 and 3 (each within the scatter of the next).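

In this assay, (2,4-dichlorophenyl)sulfanyl on a saturated chain carbon bound to a carbonyl carbon gives steps beyond the scatter from all three phenoxy compounds (a 2.7-fold lower number from compound 3 to compound 4 (0.43 log units; beyond the scatter); a 2.1-fold lower number from compound 2 to compound 4 (0.32 log units; beyond the scatter); a 2.5-fold lower number from compound 1 to compound 4 (0.40 log units; beyond the scatter)), so compound 4 has the lowest number in the set. This place in the molecule is therefore not silent in this assay, as the within-scatter steps among compounds 1, 2 and 3 alone had suggested, although the steps are modest. The change exchanges the oxygen linker for sulfur and the two methyl groups for two chlorines in one move, so the data cannot divide the step between these parts, and nothing shown bears on its cause.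

Still open, as far as these compounds go, is how 2,4-dichlorophenoxy and (2,4-dimethylphenyl)sulfanyl would read, since these two groups would separate the linker from the ring substituents. Also open, from the compounds shown here alone, is whether a longer chain between the carbonyl and the sulfur, or a carboxylic acid or an amine on the aryl ring, would shift the number further.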